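Amide substituent change in a spiro sulfone series

This account rests on a few compounds, and the source may have more. Where it says the series, first, only, none or still open, it means among the compounds named here.

Compound 3 `O=C(Nc1ccccn1)C1(S(=O)(=O)c2ccc(Oc3ccc(OC(F)(F)F)cc3)cc2)CCC2(CCNCC2)C1` is one of three related compounds with data in hand. In a functional assay on blood (Homo sapiens), with a stated time of 60 min, in the presence of a further agent that is not named here (on this read-out higher numbers stand for an effect only at larger amounts of compound and lower numbers for an effect already at smaller amounts), compound 3 gives > 15000 nM, which is a limit of the measurement and not a number. Compound 1 `COC(=O)C1(S(=O)(=O)c2ccc(Oc3ccc(OC(F)(F)F)cc3)cc2)CCC2(CCNCC2)C1` gives > 15000 nM in this assay, likewise a limit. Compound 2 `O=S(=O)(c1ccc(Oc2ccc(OC(F)(F)F)cc2)cc1)C1(CO)CCC2(CCNCC2)C1` gives > 15000 nM in this assay, also a limit. The steps a step that the two limits leave unreadable from compound 1 to compound 2, a step that the two limits leave unreadable from compound 1 to compound 3 and a step that the two limits leave unreadable from compound 2 to compound 3 therefore carry no readable size; all three compounds sit at the limit of > 15000 nM in this assay, at which 3 of the 3 values shown sit. Compound 4 `COc1ccc(N)c(NC(=O)C2(S(=O)(=O)c3ccc(Oc4ccc(OC(F)(F)F)cc4)cc3)CCC3(CCNCC3)C2)c1` differs from compound 3 in that (2-amino-5-methoxyphenyl in place of pyridin-2-yl on an amide-type nitrogen). Going by the values given here, no measured step bears on this change, and the three limits give no direction for it. Compound 4 is expected to stay at the limit, the step of a number no higher from compound 3 to compound 4 (the limit leaves the size open) being nominal only. The estimate for compound 4 is 15000 nM, with a range from 3000 nM to 50000 nM.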

Compound 4, half-maximal effective concentration: 3700 nM
Beside the measured number, compound 4's estimate is 4.1-fold (0.61 log units) above it; low and high end bracket the measured number.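

In this assay, going by these compounds alone, the amide-type nitrogen gives the first readable step, with 2-amino-5-methoxyphenyl in place of pyridin-2-yl (an at least 4.0-fold lower number from compound 3 to compound 4 (0.60 log units; beyond the scatter)). The same entering group also gives readable steps from the hydroxymethyl and methoxycarbonyl forms (an at least 4.0-fold lower number from compound 2 to compound 4 (0.60 log units; beyond the scatter)) and (an at least 4.0-fold lower number from compound 1 to compound 4 (0.60 log units; beyond the scatter)). Each step has a limit at one end, so only its minimum size is known: the limit of > 15000 nM in this assay, at which 3 of the 4 values shown sit.

Which part of the entering group carries the step stays open. So does the effect of a phenyl carrying only the amine, or only the methoxy, on this nitrogen.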